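Compound 1 and the loss of its 4-hydroxyphenyl group

This account rests on a few compounds, and the source may have more. Where it says the series, first, only, none or still open, it means among the compounds named here.

Measured in a functional assay on A549 cells (Homo sapiens) for inhibition, read by sulforhodamine B assay, with a stated time of 48 h; a higher number here means a weaker inhibitor of growth, a lower number a stronger inhibitor of growth:
- Compound 1 `COc1ccc(/C=C/C(=O)C(=Cc2ccc(O)cc2)C(=O)/C=C/c2ccc(OC)c(OC)c2)cc1OC`: 420 nM
- Compound 2 `COc1ccc(C=C(C(=O)/C=C/c2ccc(O)c(OC)c2)C(=O)/C=C/c2ccc(O)c(OC)c2)c(OC)c1`: 690 nM
- Compound 3 `COc1cccc(C=C(C(=O)/C=C/c2ccc(O)c(OC)c2)C(=O)/C=C/c2ccc(O)c(OC)c2)c1`: 640 nM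

These three values lie within the usual scatter of one another, so compound 1 cannot be ranked against compound 2 or compound 3. Compound 4 `COc1ccc(/C=C/C(=O)C(=CO)C(=O)/C=C/c2ccc(OC)c(OC)c2)cc1OC` differs from compound 1 in one place: hydroxy in place of 4-hydroxyphenyl on a double-bonded chain carbon bound to a double-bonded chain carbon. Hydroxy takes the place of 4-hydroxyphenyl on a double-bonded chain carbon bound to a double-bonded chain carbon. Among the compounds with values here, the only measured step is a 1.1-fold lower number from compound 2 to compound 3 (0.03 log units; within the scatter). It exchanges one substituted phenyl for another, so it offers weak guidance for removing that group altogether. The estimated change in this assay is a 2.9-fold higher number from compound 1 to compound 4 (0.46 log units; beyond the scatter), a tentative expectation of weaker growth inhibition. Compound 4 is expected at 1200 nM, with an estimated range of 350 nM to 4500 nM.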

Compound 4, concentration for 50% growth inhibition: > 25000 nM
Compound 4 gave a limit, no number; the forecaster's own chance of this, stated with the estimate: 10%; middle value at least 20-fold (1.31 log units) from the limit.
By their numbers in this assay, from the lowest: compounds 1, 3 and 2 (each within the scatter of the next). At a limit, above all of these: compound 4.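

Compound 4 gives a limit in this assay, not a number: the limit of > 25000 nM in this assay, at which 1 of the 4 values shown sits.

Even so, the change is large, an at least 59-fold higher number from compound 1 to compound 4 (1.77 log units; beyond the scatter), so replacing the 4-hydroxyphenyl group with hydroxy at this place costs far more growth inhibition than the scatter can account for. The earlier exchange of one substituted phenyl for another, a 1.1-fold lower number from compound 2 to compound 3 (0.03 log units; within the scatter), gave no sign of this.

From the compounds shown here alone, it remains open how much of the 4-hydroxyphenyl group is needed, and whether an unsubstituted phenyl, a methyl or an amine on this carbon would retain the growth inhibition of compound 1.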